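Inverting the chain stereocentre of a chlorinated benzodioxane acid

The compounds below may be only part of what the source reports. "The series", "measured", "known", "first", "only" and "open" are said of these compounds alone.

Measured compounds:
compound 1, `CC#CC(CC(=O)O)c1ccc(OCC2COc3ccc(Cl)cc3O2)cc1`, 100 nM 
compound 2, `Cn1nncc1C(CC(=O)O)c1ccc(OCC2COc3ccc(Cl)cc3O2)cc1`, 3870 nM 
compound 3, `CC#C[C@@H](CC(=O)O)c1ccc(OC[C@H]2COc3ccc(Cl)cc3O2)cc1`, 50 nM 

All three were tested in a functional assay on HEK293 cells for agonist activity at Free fatty acid receptor 1 (Homo sapiens), read by fluorescence and calcium flux, with a stated time of 10 min; a lower number here means that less compound is needed, a higher number that more compound is needed for the effect. Compound 3 stands at one end of the three numbers; a 2.0-fold lower number from compound 1 to compound 3 (0.30 log units; within the scatter) leaves it indistinguishable from compound 1, while compound 2 lies far off, since a 39-fold higher number from compound 1 to compound 2 (1.59 log units; beyond the scatter) is large. Compound 1 and compound 3 are the same molecule apart from drawn configuration, and the fact that one of compounds 1 and 3 is drawn with a defined configuration and the other without, at the place where they differ is the only thing that separates them.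

Compound 4, `CC#C[C@H](CC(=O)O)c1ccc(OC[C@H]2COc3ccc(Cl)cc3O2)cc1`, is not yet measured. The change is the two compounds have the same atoms and bonds and differ only in configuration as drawn: 1 of 2 stereo elements differ; a stereocentre at a saturated chain carbon is drawn S in compound 3 and R in compound 4. Among the measured compounds shown here, no measured step exchanges one drawn configuration for another; the only related step is a 2.0-fold lower number from compound 1 to compound 3 (0.30 log units; within the scatter), where the compound drawn with both centres defined gives a number on the lower side of the compound drawn with neither. If the defined isomer accounts for the activity of the undefined mixture, the opposite chain configuration should give a higher number in this assay, and the step could be sizeable. Compound 4 is therefore expected to give 1500 nM (range 300 nM to 8000 nM). That expectation corresponds to a 30-fold higher number from compound 3 to compound 4 (1.48 log units; beyond the scatter).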

Compound 4, half-maximal effective concentration: 3400 nM
Compound 4: the middle estimate sits 2.3-fold (0.36 log units) below what was measured, within the range that was stated.
By their numbers in this assay, from the lowest: compounds 3 and 1 (each within the scatter of the next); then compounds 4 and 2 (each within the scatter of the next).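

Among the compounds shown here, the chain stereocentre proves decisive in this assay: exchanging S for R at the saturated chain carbon gives a 68-fold higher number from compound 3 to compound 4 (1.83 log units; beyond the scatter), a large step that no earlier pair could show, as none exchanged one drawn configuration for another. This single centre is all that separates the pair: the fact that compounds 3 and 4 differ only in the configuration as drawn. The R isomer also stands well off from the form drawn without configurations, with a 34-fold higher number from compound 1 to compound 4 (1.53 log units; beyond the scatter), so it is the S isomer that stays within the scatter of that form.

From the compounds shown here alone, what the R configuration at the saturated ring carbon would give stays open, as both defined compounds are drawn S there. Also open, going by these compounds, is whether the S configuration remains the better one with other groups on the chain carbon, such as 1-methyl-1H-1,2,3-triazol-5-yl or a cyclopropyl group.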